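This account rests on a few compounds, and the source may have more. Where it says the series, first, only, none or still open, it means among the compounds named here.

Measured so far in a physicochemical assay for pharmacokinetics; on this read-out higher numbers stand for a longer-lived compound and lower numbers for a shorter-lived compound
- compound 1 `COc1ccc(CNC(=O)N2C(=O)c3ccccc3S2(=O)=O)cc1` gives 0.187 h
- compound 2 `O=C(NCc1ccccc1F)N1C(=O)c2ccccc2S1(=O)=O` gives 0.598 h
- compound 3 `Cc1ccccc1CNC(=O)N1C(=O)c2ccccc2S1(=O)=O` is not yet measured

Compound 2 holds the higher of the two numbers, and compound 1 the lower. Going on to compound 3 brings methyl in place of fluoro on an aromatic carbon as its only change, with methyl in place of fluoro on an aromatic carbon, ortho to a large group. Within the data shown here, no measured step makes this exchange. The nearest guide is a 3.2-fold higher number from compound 1 to compound 2 (0.50 log units; beyond the scatter) where 2-fluorophenyl took the place of 4-methoxyphenyl. That single step gives a loose upper scale only. Compound 3 also loses the fluoro that compound 2 carries, so a small downward move is expected, smaller than that step. The expected step is a 1.4-fold lower number from compound 2 to compound 3 (0.15 log units; within the scatter) in this estimate. For compound 3 the estimated value is 0.42 h with an expected range from 0.18 h to 0.95 h in this assay terms.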

Compound 3, half-life: 0.792 h
Compound 3: the middle estimate sits 1.9-fold (0.28 log units) below what was measured, and the stated range covers the measured number.
By their numbers in this assay, from the lowest: compound 1; then compounds 2 and 3 (each within the scatter of the next).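

In this assay the exchange of 2-fluorophenyl for 2-methylphenyl gives a 1.3-fold higher number from compound 2 to compound 3 (0.12 log units; within the scatter), so on this aromatic carbon, ortho to a large group, methyl and fluoro cannot be told apart on this read-out. With 2-methylphenyl in place of 4-methoxyphenyl the series shows a 4.2-fold higher number from compound 1 to compound 3 (0.63 log units; beyond the scatter), so the gap from compound 1 is not tied to fluoro and appears with either of the two groups. No measurement at hand offers a cause for these numbers.

The step from compound 1 alters both the group and where it sits, and the compounds shown cannot separate those two changes; a plain phenyl or a 2-methoxyphenyl group would bear on this. Also open, as far as these compounds go, is whether a larger group at this place, such as trifluoromethyl or an aminomethyl group, would stay level with compound 2 and compound 3.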